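The source may hold more compounds than are shown below. What is called first, only, known or untested is meant among the compounds shown, and "the series" means these compounds.

Working notes on the series. The shared core carries a 4-methylpiperazin-1-yl group and a chain on an aromatic nitrogen. In a functional assay on ileum for inhibition of histamine H1 receptor (Cavia porcellus) (a lower number here means a stronger inhibitor, a higher number a weaker inhibitor), compound 1 `CCSCCn1c(N2CCN(C)CC2)nc2ccccc21` gives 19 nM, and compound 2 `C#CCOCCn1c(N2CCN(C)CC2)nc2ccccc21` gives 12 nM; the step of a 1.6-fold lower number from compound 1 to compound 2 (0.20 log units; within the scatter) is within the scatter. Compound 3 `CCCSCn1c(N2CCN(C)CC2)nc2ccccc21` gives 68 nM in this assay, the highest of the three numbers, reached by the steps of a 3.6-fold higher number from compound 1 to compound 3 (0.55 log units; beyond the scatter) and a 5.7-fold higher number from compound 2 to compound 3 (0.75 log units; beyond the scatter), both beyond the scatter.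

Compound 4 `CN1CCN(c2nc3ccccc3[nH]2)CC1` takes the chain away altogether: hydrogen in place of (propylsulfanyl)methyl on an aromatic nitrogen. The two steps that bear on this are those into compound 3, where a change of the chain on the aromatic nitrogen raised the number modestly each time. Among the compounds with values here, no measured step removes the chain entirely, so the expectation is an extrapolation in the same direction, with a wide range. For compound 4 the expected step is a 7.4-fold higher number from compound 3 to compound 4 (0.87 log units; beyond the scatter) in this assay. Compound 4 is therefore estimated at 500 nM, within 100 nM to 3000 nM.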

Compound 4, half-maximal inhibitory concentration: > 3000 nM
Compound 4 gave a limit, no number; the forecaster's own chance of this, stated with the estimate: 10%; middle value at least 6.0-fold (0.77 log units) away from the limit.
By their numbers in this assay, from the lowest: compounds 2 and 1 (each within the scatter of the next); then compound 3. At a limit, above all of these: compound 4.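

Compound 4 gives only a limit in this assay, not a number: the limit of > 3000 nM in this assay, at which 1 of the 4 values shown sits. Hydrogen in place of the chain on the aromatic nitrogen produces the only large steps in the series: an at least 44-fold higher number from compound 3 to compound 4 (1.64 log units; beyond the scatter), an at least 250-fold higher number from compound 2 to compound 4 (2.39 log units; beyond the scatter) and an at least 150-fold higher number from compound 1 to compound 4 (2.19 log units; beyond the scatter). The earlier compounds showed that exchanging one chain for another at this position leaves the number within the scatter or moves it modestly, whereas these steps show that losing the chain altogether costs far more than any exchange among the three chains shown.

How much of the chain is needed stays open, since a methyl or ethyl group on this nitrogen would fall between hydrogen and the chains shown. Also open, from the compounds shown here alone, is whether a chain ending in an amine or a carboxylic acid would stay near compound 1 and compound 2.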